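The source may hold more compounds than are shown below. What is called first, only, known or untested is meant among the compounds shown, and "the series" means these compounds.

Compound 1, `COc1ccc(-c2cc3ccccc3nc2/C=C/C(=O)c2ccccc2)cc1`, is the starting point. Among the measured compounds shown here, in a functional assay on NCI-H460 cells (Homo sapiens) for antiproliferative activity, read by XTT assay, with a stated time of 72 h (a higher number here means a weaker inhibitor, a lower number a stronger inhibitor), compound 1 gives 6670 nM, the lowest of the three numbers recorded, although no step from it reaches beyond the scatter. Its nearest neighbour is compound 2, `COc1ccc(-c2cc3ccccc3nc2/C=C/C(=O)c2ccc(F)cc2)cc1`, which in this assay gives 6990 nM, a step of a 1.0-fold higher number from compound 1 to compound 2 (0.02 log units; within the scatter). The furthest is compound 3, `COc1ccc(-c2cc3ccccc3nc2/C=C/C(=O)c2ccc(OC)c(OC)c2)cc1`, which gives 7540 nM, a step of a 1.1-fold higher number from compound 1 to compound 3 (0.05 log units; within the scatter); between these two the step is a 1.1-fold higher number from compound 2 to compound 3 (0.03 log units; within the scatter).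

The compound not yet measured is compound 4, `COc1ccc(-c2cc3ccccc3nc2/C=C/C(=O)c2cccs2)cc1`. It differs from compound 1 in one place: thiophen-2-yl in place of phenyl on a carbonyl carbon.

For the measured compounds named here, the steps that bear on this change are those that alter the aryl group on the carbonyl carbon, namely the replacement of phenyl by 3,4-dimethoxyphenyl from compound 1 to compound 3 and of 4-fluorophenyl by 3,4-dimethoxyphenyl from compound 2 to compound 3. Both were within the scatter, as was the step from compound 1 to compound 2. Going by the values given here, nothing among the measured compounds points to a move in either direction, so no step beyond the scatter is expected, and compound 4 is expected to show a 1.0-fold higher number from compound 1 to compound 4 (0.02 log units; within the scatter). Compound 4 is accordingly estimated at 7000 nM in this assay, with a range from 3500 nM to 14000 nM.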

Compound 4, half-maximal inhibitory concentration: 5440 nM
Beside the measured number, compound 4's estimate is 1.3-fold (0.11 log units) above it, within the range that was stated.
By their numbers in this assay, from the lowest: compounds 4, 1, 2 and 3 (each within the scatter of the next).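

Until now the aryl group on the carbonyl carbon had been varied only among phenyl rings, and compound 4 extends that range to a five-membered aromatic ring with a sulfur hetero atom. In this assay, this change gives a 1.2-fold lower number from compound 1 to compound 4 (0.09 log units; within the scatter), and the comparisons with the substituted phenyl rings give a 1.3-fold lower number from compound 2 to compound 4 (0.11 log units; within the scatter) and a 1.4-fold lower number from compound 3 to compound 4 (0.14 log units; within the scatter), so neither the smaller ring nor the hetero atom produces a step beyond the scatter at this position. No measurement is available that would explain these small steps.

With all four compounds lying so close together, the series does not yet show whether any group on this carbonyl carbon can shift the number beyond the scatter, and a ring carrying an amine or a carboxylic acid, or a longer chain in place of the ring, remains an open test of that question. As far as these compounds go, it is also open whether changes elsewhere on the core of compound 1, such as replacing the methoxy group, would produce larger steps than those seen at this position in this assay.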